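Methylsulfanyl for methyl on the aminopyrimidine-free alkyne core

The source may hold more compounds than are shown below. What is called first, only, known or untested is meant among the compounds shown, and "the series" means these compounds.

Measured so far:
compound 1 `CNc1ncc(C#Cc2ccc(C)cc2)cn1`: 704000 nM
compound 2 `Cc1cccc(C#Cc2cnc(C)nc2)c1`: "not active" (no number reported)
compound 3 `CCNc1ncc(C#Cc2ccccc2)cn1`: "not active" (no number reported)

Among the measured compounds shown here, in an assay on HEK293 cells for positive allosteric modulation of metabotropic glutamate receptor 5 (Rattus norvegicus) (a higher number here means that more compound is needed for the effect, a lower number that less compound is needed), compound 1 gives 704000 nM, the only numerical value in the set. Compound 2 is reported in this assay as "not active" (no number reported), so it stands without a number; compound 3 is likewise reported in this assay as "not active" (no number reported). For the measured compounds named here, no pair of measured compounds differs in one place, so no step size is known from measurements.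

Compound 4 `CSc1ncc(C#Cc2cccc(C)c2)cn1` is not yet measured. It differs from compound 2 in one place: methylsulfanyl in place of methyl on an aromatic carbon. The change sits on an aromatic carbon of a six-membered aromatic ring with two nitrogens, between the two ring nitrogen atoms.

With compound 2 giving no number in this assay, the expectation for compound 4 rests only on the weak value of compound 1. A step in this assay from compound 2 to compound 4 toward lower numbers is expected, but its size cannot be anchored, and a further report without a number remains likely. For compound 4 the estimated value in this assay is 500000 nM, with a range from 100000 nM to 2000000 nM.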

Compound 4, half-maximal effective concentration: "not active" (no number reported)
Nothing numeric was reported for compound 4, so the estimate cannot be set against anything.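

In this assay compound 2 and compound 4 are both reported as not active, so no step can be read for methylsulfanyl in place of methyl. No measured evidence bears on this result. The compounds shown leave open whether this change alters the response at all.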